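A few compounds are considered here, and "the series" means these few. Any claim that something is new, unique, unknown or untested is made for them only; others in the source may bear on it.

Of the compounds shown here, two have so far been tested in a functional assay on BT-549 cells (Homo sapiens) for cytotoxicity, read by sulforhodamine B assay, with a stated time of 48 h, tested at 0.1 uM; on this read-out lower numbers stand for a stronger effect and higher numbers for a weaker effect at the one concentration tested. Compound 1 `COc1cc(-c2cc(/C=C/C(=O)c3ccc(N)cc3)[nH]n2)cc(OC)c1OC` carries a 4-aminophenyl group on its carbonyl carbon, and in this assay compound 1 gives 93%. Compound 2 `COc1ccc(-c2cc(/C=C/C(=O)c3ccc(OC)c(OC)c3)[nH]n2)cc1` gives 105% in this assay. For the measured compounds named here, compound 1 thus holds the lower of the two numbers, and its gap to compound 2 lies beyond the usual scatter of repeated runs, so at the single concentration tested compound 1 shows the stronger effect of the pair, though neither number points to a large effect.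

Compound 3 `COc1cc(-c2cc(/C=C/C(=O)c3ccc(Cl)c(Cl)c3)[nH]n2)cc(OC)c1OC` has not yet been measured. It differs from compound 1 in one place: 3,4-dichlorophenyl in place of 4-aminophenyl on a carbonyl carbon. Going by the values given here, no pair of measured compounds differs in exactly this exchange. The expectation therefore rests only on the numbers at hand. Because compound 1 gives 93% in this assay, compound 3 is expected to stay close to that level. The expected step of a number 2 percentage points higher from compound 1 to compound 3 (within the scatter) is small and is not expected to exceed the scatter in either direction. Compound 3 is therefore estimated at 95% in this assay, with a range from 80% to 110%.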

Compound 3, a percentage reported as activity, at one concentration (the size of the read-out at that concentration, not a potency): 95%
Compound 3: the middle estimate sits on the measured number at the digits printed, and the stated range covers the measured number.
By their numbers in this assay, from the lowest: compounds 1, 3 and 2 (each within the scatter of the next, the first and the last beyond it).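

For the compounds shown here, the exchange of 4-aminophenyl for 3,4-dichlorophenyl on a carbonyl carbon gives the first step between compounds that differ in one place: in this assay, it is a number 2 percentage points higher from compound 1 to compound 3 (within the scatter). At this position, therefore, a group with one hydrogen-bond donor and one hydrogen-bond acceptor and a group with neither cannot be told apart at the one concentration tested, even though the entering group also carries the two chlorine atoms. No measurement is at hand that would explain this result.

The compounds shown leave open whether another kind of group on this carbonyl carbon, such as a 4-carboxyphenyl group or a pentyl chain, would produce a step beyond the scatter. Going by these compounds alone, they also leave open whether compound 1 and compound 3 would still read alike at other concentrations, as a single-concentration read-out gives no potency for either compound.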